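The compounds below may be only part of what the source reports. "The series", "measured", "known", "first", "only" and "open" are said of these compounds alone.

Working notes on the amide series. Compound 1 `COc1ccc2nc(C)cc(OCC(=O)Nc3cccc(C)c3)c2c1` is the reference; in a toxicity assay on HepG2 cells (Homo sapiens) for inhibition, read by CellTiter-Glo, with a stated time of 48 h (on this read-out lower numbers stand for stronger inhibition and higher numbers for weaker inhibition), compound 1 gives 39800 nM. Compound 2 `COc1ccc2nc(C)cc(OCC(=O)Nc3ccc(Cl)cc3)c2c1` differs only at the amide-type nitrogen. In this assay compound 2 reports only an assay limit, > 100000 nM, and no number. Compound 3 `COc1ccc2nc(C)cc(OCC(=O)Nc3ccccn3)c2c1` carries a pyridin-2-yl group on the amide-type nitrogen. In this assay compound 3 likewise reports only a limit, > 100000 nM. Compound 3 thus stands at the limit of > 100000 nM in this assay, at which 2 of the 3 values shown sit, together with one other member. The measured steps are an at least 2.5-fold higher number from compound 1 to compound 2 (0.40 log units; beyond the scatter) and an at least 2.5-fold higher number from compound 1 to compound 3 (0.40 log units; beyond the scatter); between the two limit values there is a step that the two limits leave unreadable from compound 2 to compound 3. Compound 4 `COc1ccc2nc(C)cc(OCC(=O)Nc3ccncn3)c2c1` carries the change (pyrimidin-4-yl in place of pyridin-2-yl on an amide-type nitrogen). Going by the values given here, the readable steps bear on this change only indirectly: both swaps away from the reference ring on the amide-type nitrogen ran into the limit, and no step from one limit compound to another can be sized. Compound 4 is therefore expected to stay at or near the limit, with an estimated step that the limit leaves unreadable from compound 3 to compound 4 and no direction beyond the scatter. The estimate for compound 4 is 150000 nM, within a range from 40000 nM to 500000 nM.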

Compound 4, half-maximal inhibitory concentration: > 100000 nM
Compound 4 was reported as a limit (the forecaster's own chance of this, stated with the estimate: 75%); the middle value lies beyond the limit too.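

In this assay, going by these compounds alone, the reading for compound 4 is a limit and not a number, so a second ring nitrogen in pyrimidin-4-yl brings no readable return towards compound 1, and the one readable step is an at least 2.5-fold higher number from compound 1 to compound 4 (0.40 log units; beyond the scatter). The steps to compound 4 from compound 2 and from compound 3 cannot be read, as both ends of each are limits. With a third, different group on the amide-type nitrogen at the same limit, compound 1 remains the only exception at this position: the limit of > 100000 nM in this assay, at which 3 of the 4 values shown sit.

Going by these compounds, how far compound 2, compound 3 and compound 4 lie past the limit stays open, and with it any order among them. Also open, on these data alone, is whether the number for compound 1 needs its methyl group, which a plain phenyl or a cyclohexyl group on the amide-type nitrogen would bear on.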